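From (diethylamino)methyl to methylcarbamoyl on the shared core

The source may hold more compounds than are shown below. What is called first, only, known or untested is meant among the compounds shown, and "the series" means these compounds.

In a functional assay on HCT-116 cells (Homo sapiens) for inhibition (a lower number here means a stronger inhibitor, a higher number a weaker inhibitor), compound 1 `CCNC(=O)c1noc(-c2cc(C(C)C)c(O)cc2O)c1-c1cc(CNC(C)=O)no1` gives 167 nM and compound 2 `CCNC(=O)c1noc(-c2cc(C(C)C)c(O)cc2O)c1-c1cc(CN(CC)CC)no1` gives 38 nM, the lower of the two numbers. Compound 3 `CCNC(=O)c1noc(-c2cc(C(C)C)c(O)cc2O)c1-c1cc(C(=O)NC)no1` differs from compound 2 as follows: methylcarbamoyl in place of (diethylamino)methyl on an aromatic carbon. Among the compounds with values here, only one measured step bears on this change: a 4.4-fold lower number from compound 1 to compound 2 (0.64 log units; beyond the scatter), modest but beyond the scatter. Compound 1, with its acetamido group, is the closer guide to an amide-bearing side group, at 167 nM, so a higher number is expected. The expected change is a 2.9-fold higher number from compound 2 to compound 3 (0.46 log units; beyond the scatter), of similar size. Compound 3 is estimated at 110 nM, with an expected range of 35 nM to 350 nM.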

Compound 3, half-maximal inhibitory concentration: 124 nM
Compound 3: middle estimate off by 1.1-fold (0.05 log units), on the low side, and the stated range covers the measured number.
By their numbers in this assay, from the lowest: compound 2; then compounds 3 and 1 (each within the scatter of the next).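

Methylcarbamoyl on this aromatic carbon does not keep the number of (diethylamino)methyl (a 3.3-fold higher number from compound 2 to compound 3 (0.51 log units; beyond the scatter)). Methylcarbamoyl and the acetamidomethyl group of compound 1 cannot be told apart (a 1.3-fold lower number from compound 1 to compound 3 (0.13 log units; within the scatter)). Among the side groups shown, the two amide-bearing groups therefore sit together, and only the (diethylamino)methyl of compound 2 stands apart from them.

Nothing at hand gives a reason for this difference. Still open, as far as these compounds go, is how a smaller amine such as dimethylaminomethyl, a morpholinomethyl group or a carboxylic acid at this place would compare with compound 2.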